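Replacing 3-methoxyphenoxy with 4-fluorobenzyl on the shared core

This account rests on a few compounds, and the source may have more. Where it says the series, first, only, none or still open, it means among the compounds named here.

In an ADME assay on HepG2 cells (Homo sapiens) for cytotoxicity, read by luminescence, CellTiter-Glo and ATP content, with a stated time of 72 h (on this read-out higher numbers stand for an effect only at larger amounts of compound and lower numbers for an effect already at smaller amounts), compound 1 (`c1ccc(CCc2ccc3c(NCCCNCc4ccco4)ccnc3c2)cc1`) gives 16000 nM and compound 2 (`COc1cccc(Oc2ccc3c(NCCCNCc4ccco4)ccnc3c2)c1`) gives 15500 nM so the two stand level within the scatter. Compound 3 (`Fc1ccc(Cc2ccc3c(NCCCNCc4ccco4)ccnc3c2)cc1`) carries 4-fluorobenzyl in place of 3-methoxyphenoxy on an aromatic carbon of the shared core (4-fluorobenzyl in place of 3-methoxyphenoxy on an aromatic carbon). Among the measured compounds shown here, the only measured step at this carbon, 3-methoxyphenoxy in place of phenethyl, is a 1.0-fold lower number from compound 1 to compound 2 (0.01 log units; within the scatter) and on that evidence no step beyond the scatter is expected in this assay for the new group. That expectation amounts to an estimated 1.0-fold lower number from compound 2 to compound 3 (0.01 log units; within the scatter) and no direction can be favoured. It rests on just two measured compounds, so the range is kept wide. Compound 3 is estimated at 15000 nM with an expected range from 8000 nM to 28000 nM on this read-out.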

Compound 3, half-maximal effective concentration: 5600 nM
Beside the measured number, compound 3's estimate is 2.7-fold (0.43 log units) above it; measured number outside the range, below it.
By their numbers in this assay, from the lowest: compound 3; then compounds 2 and 1 (each within the scatter of the next).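

In this assay, among the compounds shown here, this aromatic carbon proves not to be indifferent to its substituent: the change gives a 2.8-fold lower number from compound 2 to compound 3 (0.44 log units; beyond the scatter) and is the first step here to lie beyond the scatter, whereas phenethyl and 3-methoxyphenoxy had stood level. Read as 4-fluorophenyl in place of benzyl on the saturated chain carbon, the change gives a 2.9-fold lower number from compound 1 to compound 3 (0.46 log units; beyond the scatter) and is also modest, so compound 3 stands apart from both earlier compounds. The effect therefore appears at smaller amounts of compound with 4-fluorobenzyl at this carbon than with either earlier group.

The compounds shown leave open whether the step belongs to the fluorine or to the rest of the 4-fluorobenzyl group, and what a plain benzyl group or a morpholine would give at this carbon. No evidence at hand accounts for the step.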